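The source may hold more compounds than are shown below. What is called first, only, known or untested is meant among the compounds shown, and "the series" means these compounds.

Compound 1 (`C=CS(=O)(=O)N1CCN(c2ncnc3sc(-c4ccc(N5CCN(C)CC5)cc4)cc23)[C@@H](C)C1`) gives 6920 nM
Compound 2 (`CCS(=O)(=O)N1CCN(c2ncnc3sc(-c4ccc(N5CCN(C)CC5)cc4)cc23)CC1`) gives 10600 nM

Both values come from a functional assay on MDA-MB-436 cells (Homo sapiens) for antiproliferative activity, read by MTT assay, with a stated time of 48 h (a lower number here means a stronger inhibitor, a higher number a weaker inhibitor), and lie within the usual scatter of each other, so compound 2 stands level with compound 1 on these numbers. Compound 3 (`CN1CCN(c2ccc(-c3cc4c(N5CCN(C(=O)Nc6ccc(C#N)cc6)CC5)ncnc4s3)cc2)CC1`) keeps the rest of compound 2, but (4-cyanophenyl)carbamoyl comes in place of ethylsulfonyl on an amine nitrogen in a ring ((4-cyanophenyl)carbamoyl in place of ethylsulfonyl on an amine nitrogen in a ring). Going by the values given here, no measured pair shows what a change at this place does, so the expectation starts from compound 2 at 10600 nM and stays broad. A modest move towards a lower number is expected, and the expected step is small enough that the measurement could well fall close to the starting value (a 2.1-fold lower number from compound 2 to compound 3 (0.33 log units; beyond the scatter)). For compound 3 the estimated value is 5000 nM, with an expected range from 1200 nM to 20000 nM.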

Compound 3, half-maximal inhibitory concentration: 5010 nM
The estimate for compound 3 lay 1.0-fold (0.00 log units) below the measured number, and the stated range covers the measured number.
By their numbers in this assay, from the lowest: compounds 3, 1 and 2 (each within the scatter of the next, the first and the last beyond it).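

Up to this point no step at this place could be read. In this assay, (4-cyanophenyl)carbamoyl in place of ethylsulfonyl on an amine nitrogen in a ring gives a 2.1-fold lower number from compound 2 to compound 3 (0.33 log units; beyond the scatter), so this position takes a much larger group, with one six-membered aromatic ring of carbon only and a hydrogen-bond donor, without any loss of activity and with a modest gain. Nothing at hand accounts for this step or assigns it to the carbonyl, the aromatic ring or the nitrile.

On these data alone, whether the nitrile matters, or whether a methoxy group, a carboxylic acid or plain hydrogen at that spot on the aromatic ring would serve equally, remains open. Also open, as far as these compounds go, is what a simple acetyl group or a longer alkyl chain would do on the same nitrogen.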